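The compounds below may be only part of what the source reports. "The series", "measured", "known", "first", "only" and "open" are said of these compounds alone.

Compound 1 `COc1ccccc1OCC1SCCN1C(=O)C[S+](C)[O-]`: 25 mg/kg
Compound 2 `COc1ccccc1OCC1SCCN1C(=O)CN`: 57 mg/kg
Compound 3 `COc1ccccc1OCC1SCCN1C(=O)CNC(C)=O`: 40 mg/kg

In a functional assay on the whole organism for inhibition, with Cavia porcellus as the target (a lower number here means that less compound is needed, a higher number that more compound is needed for the effect), compound 3, at 40 mg/kg, lies within the scatter of both other compounds. Compound 4 `COc1ccccc1OCC1SCCN1C(=O)Cn1ccnc1` differs from it as follows: 1H-imidazol-1-yl in place of acetamido on a saturated chain carbon bound to a carbonyl carbon. In words, this is 1H-imidazol-1-yl in place of acetamido on a saturated chain carbon bound to a carbonyl carbon.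

Three measured steps changed the same place. Two stayed within the scatter: a 1.6-fold higher number from compound 1 to compound 3 (0.20 log units; within the scatter) and a 1.4-fold lower number from compound 2 to compound 3 (0.15 log units; within the scatter). The largest was modest: a 2.3-fold higher number from compound 1 to compound 2 (0.36 log units; beyond the scatter). None of the three introduces a ring, so the evidence is indirect, and no step beyond the scatter is expected. The expected change is a 1.1-fold lower number from compound 3 to compound 4 (0.06 log units; within the scatter). For compound 4 the estimated value is 35 mg/kg, with an expected range of 15 mg/kg to 80 mg/kg.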

Compound 4, dose for half-maximal effect: 50 mg/kg
Compound 4: middle estimate off by 1.4-fold (0.15 log units), on the low side, and the stated range covers the measured number.
By their numbers in this assay, from the lowest: compounds 1, 3, 4 and 2 (each within the scatter of the next, the first and the last beyond it).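

Read in this assay, the first ring at this place, 1H-imidazol-1-yl, gives a 1.3-fold higher number from compound 3 to compound 4 (0.10 log units; within the scatter) and a 1.1-fold lower number from compound 2 to compound 4 (0.06 log units; within the scatter) and so stays level with both the acetamido and the amino group. Against the sulfur-bearing group it gives a 2.0-fold higher number from compound 1 to compound 4 (0.30 log units; within the scatter) and also stays within the scatter, so on a saturated chain carbon bound to a carbonyl carbon, a five-membered aromatic ring sits in the same band as the groups without a ring. Nothing measured here gives a cause for this.

Going by these compounds, whether a carboxylic acid, a phenyl ring or a longer chain at this place would leave that band remains open.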